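Furan Replaces Benzodioxin on the Pyridine Core

The compounds below may be only part of what the source reports. "The series", "measured", "known", "first", "only" and "open" are said of these compounds alone.

The three measured compounds share one core and differ only in the aryl group attached to it. In an assay on CHO cells for antagonist activity at transient receptor potential cation channel subfamily V member 1 (Homo sapiens), read by FLIPR (a lower number here means a stronger inhibitor, a higher number a weaker inhibitor), compound 1 `CC(C(=O)NCc1ccc(C(F)(F)F)nc1-c1ccc(F)c(Cl)c1)c1ccc(NS(C)(=O)=O)c(F)c1` gives 0.2 nM, and compound 2 `Cc1cc(-c2nc(C(F)(F)F)ccc2CNC(=O)C(C)c2ccc(NS(C)(=O)=O)c(F)c2)ccc1F` gives 0.4 nM, the two lying within the scatter of each other, as the step of a 2.0-fold higher number from compound 1 to compound 2 (0.30 log units; within the scatter) shows. Compound 3 `CC(C(=O)NCc1ccc(C(F)(F)F)nc1-c1ccc2c(c1)OCCO2)c1ccc(NS(C)(=O)=O)c(F)c1` gives 5 nM and stands highest of the three, weaker than both by a clear margin: a 25-fold higher number from compound 1 to compound 3 (1.40 log units; beyond the scatter) and a 13-fold higher number from compound 2 to compound 3 (1.10 log units; beyond the scatter).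

Compound 4 `CC(C(=O)NCc1ccc(C(F)(F)F)nc1-c1ccco1)c1ccc(NS(C)(=O)=O)c(F)c1` differs from compound 3 in one place: furan-2-yl in place of 2,3-dihydro-1,4-benzodioxin-6-yl on an aromatic carbon. Among the measured compounds shown here, no measured step swaps in a five-membered aromatic ring at this position, so nothing bears directly on the change. What the measured steps do show is that this position is sensitive: the two steps into compound 3 are both large, and the bicyclic group sits far behind the two small substituted phenyls. Furan-2-yl is smaller than either of those and carries no halogen, so there is no reason drawn from these three compounds to expect a return to the level of compound 1.

Compound 4 is therefore expected to lose further ground, and the estimate for compound 4 in this assay is 20 nM, with a range from 3 nM to 150 nM, a step of a 4.0-fold higher number from compound 3 to compound 4 (0.60 log units; beyond the scatter) in the weakening direction.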

Compound 4, inhibition constant: 5.8 nM
Beside the measured number, compound 4's estimate is 3.4-fold (0.54 log units) above it; the measured number falls inside the stated range.
By their numbers in this assay, from the lowest: compounds 1 and 2 (each within the scatter of the next); then compounds 3 and 4 (each within the scatter of the next).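

In this assay, exchanging 2,3-dihydro-1,4-benzodioxin-6-yl, with 10 heavy atoms, for furan-2-yl, with 5 heavy atoms, gives a 1.2-fold higher number from compound 3 to compound 4 (0.06 log units; within the scatter), so these two groups cannot be told apart at this position despite the difference in heavy-atom count. Both substituted phenyl compounds remain clearly separated from the furan, with a 15-fold higher number from compound 2 to compound 4 (1.16 log units; beyond the scatter) and a 29-fold higher number from compound 1 to compound 4 (1.46 log units; beyond the scatter), so the four compounds now form two levels: compound 1 and compound 2 at the lower numbers, compound 3 and compound 4 at the higher ones. Nothing available explains why the groups fall into these two levels.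

The compounds shown leave open which feature of the 3-chloro-4-fluorophenyl and 4-fluoro-3-methylphenyl groups separates them from the other two, and an unsubstituted phenyl, a 4-fluorophenyl or a 3-chlorophenyl at this position would place the first test on that question. They also leave open whether a thiophen-2-yl ring would fall with the furan, and whether an amine such as piperidin-1-yl would be accepted here at all.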